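The source may report more compounds than this note shows. Statements on the series, on what has been measured and on what is new or still open speak of the compounds shown alone.

For the measured compounds named here, compound 2 `O=S(=O)(c1ccccc1)c1nc2ccccc2nc1N1CCCC(O)C1` carries the shared core and in a functional assay on HCT-116 cells (Homo sapiens) for cytotoxicity, read by MTT assay, with a stated time of 72 h (on this read-out lower numbers stand for stronger inhibition and higher numbers for weaker inhibition), compound 2 gives 1390 nM, the only number measured so far. Compound 1 `O=S(=O)(c1ccc(Br)cc1)c1nc2ccccc2nc1N1CCc2ccccc2C1` gives only a limit of > 50000 nM in this assay, which is the limit of > 50000 nM in this assay, at which 1 of the 2 values shown sits. Compound 3 `O=S(=O)(c1ccc(Br)cc1)c1nc2ccccc2nc1N1CCCC(O)C1` differs from compound 2 by bromo in place of hydrogen on an aromatic carbon. Going by the values given here, no measured pair isolates this change, so the expected step of a 1.4-fold higher number from compound 2 to compound 3 (0.16 log units; within the scatter) is small, within the usual scatter or at most a mild weakening. Compound 3 is therefore estimated at 2000 nM, with a likely range from 700 nM to 8000 nM.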

Compound 3, half-maximal inhibitory concentration: 2110 nM
The estimate for compound 3 lay 1.1-fold (0.02 log units) below the measured number; the range from low to high includes it.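

Swapping phenyl for 4-bromophenyl gives a 1.5-fold higher number from compound 2 to compound 3 (0.18 log units; within the scatter), so in this assay bromo at this position brings no change that stands out from the scatter. With 4-bromophenyl held fixed, the other substituent on the shared core counts for far more, with 3-hydroxypiperidin-1-yl in place of 1,2,3,4-tetrahydroisoquinolin-2-yl giving an at least 23-fold lower number from compound 1 to compound 3 (1.37 log units; beyond the scatter). The value of compound 1 is a limit: the limit of > 50000 nM in this assay, at which 1 of the 3 values shown sits.

As far as these compounds go, whether a methoxy group or a carboxylic acid at this position of the phenyl ring would be tolerated as bromo is remains open. So does the role of the hydroxyl on the piperidine ring.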